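Aryl triazenes: estimating an amide analogue from neighbouring compounds

The compounds below may be only part of what the source reports. "The series", "measured", "known", "first", "only" and "open" are said of these compounds alone.

Measured compounds and their values in a functional assay on L1210 cells (Mus musculus) for antiproliferative activity; a higher number here means a more potent compound, by a factor of ten per unit of this negative logarithm, a lower number a less potent compound:
compound 1 `CN(C)/N=N/c1ccc(C(N)=O)cc1`, 3.51;
compound 2 `CC(C)N(C)/N=N/c1ccc(C(N)=O)cc1`, 3.17;
compound 3 `CCCCN(C)/N=N/c1ccc(CCC(=O)OCC)cc1`, 3.02.

Compound 3 has the lowest of the three numbers in this assay; compound 2 sits within the scatter of it, while compound 1 lies beyond the scatter above it. Among the compounds with values here, the only step between two compounds differing in one place is a number 0.34 log units lower from compound 1 to compound 2 (beyond the scatter), a modest fall on changing the amine substituent, and it does not touch the aromatic substituent.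

Compound 4 `CCCCN(C)/N=N/c1ccc(C(N)=O)cc1` arises from compound 3 by the change (carbamoyl in place of 2-(ethoxycarbonyl)ethyl on an aromatic carbon). Within the data shown here, no measured pair isolates this change, so the expectation rests on compound 2, which shares the carbamoyl group and gives 3.17. Compound 4 is therefore expected near that level, with a step of a number 0.18 log units higher from compound 3 to compound 4 (within the scatter) from compound 3, within the scatter. The estimate for compound 4 is 3.2, ranging from 2.8 to 3.6.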

Compound 4, logarithm of the reciprocal of the active concentration, log(1/C): 3.47
Estimate against measurement, compound 4: 0.27 log units below, and the stated range covers the measured number.
By their numbers in this assay, from the lowest: compounds 3, 2, 4 and 1 (each within the scatter of the next, the first and the last beyond it).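

In this assay, within the data shown here, the carbamoyl group on the aromatic carbon, with the butyl-bearing amine kept the same, gives the first single-change reading at this position (a number 0.45 log units higher from compound 3 to compound 4 (beyond the scatter)). On the amine side, butyl does not repeat the drop seen with isopropyl, as the two remaining steps are both within the scatter (a number 0.30 log units higher from compound 2 to compound 4 (within the scatter)) and (a number 0.04 log units lower from compound 1 to compound 4 (within the scatter)). No evidence accompanies these numbers to account for them.

The compounds shown leave open how a carboxylic acid or a nitrile would behave on this aromatic carbon. They also leave open whether a longer chain on the amine nitrogen would stay at the level of compound 4.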